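The source may hold more compounds than are shown below. What is called first, only, known or untested is meant among the compounds shown, and "the series" means these compounds.

Measured in a functional assay on HepG2 cells (Homo sapiens) for inhibition, read by MTT assay, with a stated time of 3 days; a higher number here means a weaker inhibitor, a lower number a stronger inhibitor:
- compound 1 `COc1cc(-c2nc3ccccc3s2)ccc1OCC(=O)NNC(=O)CN(C(C)=O)[C@@H](CS)C(=O)O`: 3420 nM
- compound 2 `COc1cc(-c2nc3ccccc3s2)ccc1OCC(=O)NNC(=O)CN1CCC[C@H]1C(=O)O`: 2650 nM

Among the measured compounds shown here, compound 2, at 2650 nM, cannot be separated from the only other measured compound: a 1.3-fold lower number from compound 1 to compound 2 (0.11 log units; within the scatter). Compound 3 `CCOC(=O)[C@H](NCC(=O)NNC(=O)COc1ccc(-c2nc3ccccc3s2)cc1OC)[C@@H](C)CC` is not yet measured. It carries (1-(ethoxycarbonyl)-2-methylbutyl)amino in place of 2-carboxypyrrolidin-1-yl on a saturated chain carbon bound to a carbonyl carbon. For the measured compounds named here, the one measured step made at this place is small, but it is only a single guide, so the range stays wide. No change beyond the scatter is expected in this assay, and the estimated step is a 1.1-fold lower number from compound 2 to compound 3 (0.03 log units; within the scatter). The expected value for compound 3 is 2500 nM, with an estimated range of 900 nM to 7000 nM.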

Compound 3, half-maximal inhibitory concentration: 3970 nM
Compound 3: middle estimate off by 1.6-fold (0.20 log units), on the low side; the range from low to high includes it.
By their numbers in this assay, from the lowest: compounds 2, 1 and 3 (each within the scatter of the next).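

In this assay, a ring-free (1-(ethoxycarbonyl)-2-methylbutyl)amino group replaces the ring of 2-carboxypyrrolidin-1-yl with a 1.5-fold higher number from compound 2 to compound 3 (0.18 log units; within the scatter), while replacing acetyl(1-carboxy-2-sulfanylethyl)amino with it gives a 1.2-fold higher number from compound 1 to compound 3 (0.06 log units; within the scatter). So on this saturated chain carbon bound to a carbonyl carbon, an ethyl ester in a ring-free group reads the same as the two carboxyl-bearing groups, within the scatter. Nothing available explains this result. 

Still open, from the compounds shown here alone, is whether a much smaller group, such as a plain amine, or a phenyl ring at this place would move the number beyond the scatter.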